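Swapping an Amide for an Ester on a CDK8 Inhibitor

The compounds below may be only part of what the source reports. "The series", "measured", "known", "first", "only" and "open" are said of these compounds alone.

Three measured compounds share one core, a pyridine bearing a bicyclic aromatic group and a short carbonyl-ended side chain. In an assay on a protein complex for inhibition of CDK8/Cyclin C (Homo sapiens), with a stated time of 1 h (on this read-out higher numbers stand for weaker inhibition and lower numbers for stronger inhibition), compound 1 `CNC(=O)CCc1ccncc1-c1ccc2ccccc2c1` gives 21.1 nM, the lowest of the three numbers and therefore the strongest inhibition seen so far. Compound 2 `O=C(/C=C/c1ccncc1-c1ccc2cc[nH]c2c1)N1CCOCC1` gives 43.9 nM in this assay, a gap from compound 1 that lies beyond the usual scatter, and compound 3 `CNC(=O)/C=C/c1ccncc1-c1ccc2c(ccn2C)c1` gives 77.6 nM, the furthest from compound 1, also beyond the scatter.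

Compound 4 `COC(=O)CCc1ccncc1-c1ccc2ccccc2c1` has not yet been measured. It differs from compound 1 in a single place: methoxy in place of methylamino on a carbonyl carbon. The side chain keeps its length and its carbonyl; only the group attached to that carbonyl carbon changes, so that one hydrogen-bond donor leaves and one hydrogen-bond acceptor enters.

Among the measured compounds shown here, no pair of measured compounds isolates this kind of change, so the size of the step rests on general experience with amide-to-ester swaps, which often cost some potency. A moderate weakening is expected, with the step of a 2.1-fold higher number from compound 1 to compound 4 (0.33 log units; beyond the scatter) likely beyond the scatter but not large. Compound 4 is therefore estimated at 45 nM in this assay, within a range from 15 nM to 150 nM.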

Compound 4, half-maximal inhibitory concentration: 259 nM
Compound 4: middle estimate off by 5.8-fold (0.76 log units), on the low side; measured number outside the range, above it.
By their numbers in this assay, from the lowest: compound 1; then compounds 2 and 3 (each within the scatter of the next); then compound 4.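

In this assay, putting methoxy in place of methylamino on a carbonyl carbon brings a large loss, with a 12-fold higher number from compound 1 to compound 4 (1.09 log units; beyond the scatter), so this position is far from indifferent to the group attached to that carbonyl. The earlier compounds shown here could not show this, as no two of them differ in one place only, whereas compound 1 and compound 4 keep the same side-chain length and the same carbonyl and exchange two heavy atoms for two heavy atoms, with one hydrogen-bond donor leaving and one hydrogen-bond acceptor entering. No measurement bears on the reason for the size of this step, and the loss of the donor and the gain of the acceptor cannot be told apart in this single change.

The compounds shown leave open how dimethylamino or a plain amino group on the same carbonyl carbon would compare with methylamino, a comparison that would help separate the role of the amide hydrogen from that of the nitrogen. Also open, from the compounds shown here alone, is how a carboxylic acid, or a longer chain ending in the same methylamide, would fare on the core of compound 1.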